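Amide nitrogen substituents: isopropyl to tert-butyl

The compounds below may be only part of what the source reports. "The series", "measured", "known", "first", "only" and "open" are said of these compounds alone.

Measured so far:
compound 1, `O=C(NCCO)c1cc(-c2ccc(Cl)cc2Cl)n[nH]1` — 44 nM
compound 2, `CC(C)NC(=O)c1cc(-c2ccc(Cl)cc2Cl)n[nH]1` — 51 nM

In an assay on isolated protein for inhibition of alkaline phosphatase, tissue-nonspecific isozyme (Homo sapiens) (on this read-out higher numbers stand for weaker inhibition and lower numbers for stronger inhibition), compound 1 gives 44 nM, and in this assay compound 2 gives 51 nM. Of the two numbers shown, that of compound 2 is the higher, but a 1.2-fold higher number from compound 1 to compound 2 (0.06 log units; within the scatter) lies within the scatter, so the two compounds cannot be told apart on these data.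

Compound 3 `CC(C)(C)NC(=O)c1cc(-c2ccc(Cl)cc2Cl)n[nH]1` differs from compound 2 by methyl in place of hydrogen on a saturated chain carbon bound to an amide-type nitrogen and two saturated chain carbons. For the measured compounds named here, only one measured step bears on this: a 1.2-fold higher number from compound 1 to compound 2 (0.06 log units; within the scatter), which also changes the group on the amide-type nitrogen and did not move the number beyond the scatter. Going by the values given here, no measured step adds a methyl on the branch carbon itself, so the bearing of that exact change remains open. Among the compounds with values here, on the single relevant step, a further alkyl change at this position is expected to give no step beyond the scatter, either way. For compound 3 the expected step is therefore a 1.2-fold higher number from compound 2 to compound 3 (0.07 log units; within the scatter). Compound 3 is estimated at 60 nM, with a range of 25 nM to 150 nM.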

Compound 3, half-maximal inhibitory concentration: 398 nM
Compound 3: the middle estimate sits 6.6-fold (0.82 log units) below what was measured, outside the stated range (above it).
By their numbers in this assay, from the lowest: compounds 1 and 2 (each within the scatter of the next); then compound 3.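

In this assay, the group on the amide-type nitrogen is not a freely exchangeable position: the single added methyl that turns isopropyl into tert-butyl gives a 7.8-fold higher number from compound 2 to compound 3 (0.89 log units; beyond the scatter), whereas the earlier exchange of 2-hydroxyethyl for isopropyl stayed within the scatter. The comparison with the 2-hydroxyethyl amide gives the same picture, with a 9.0-fold higher number from compound 1 to compound 3 (0.96 log units; beyond the scatter), so tert-butyl separates from both other groups while those two cannot be told apart. Among these three compounds, the first change beyond the scatter therefore appears only with the third methyl on the saturated chain carbon bound to the amide-type nitrogen, and not with the earlier change of group at this position. Nothing on hand accounts for this step.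

Still open, as far as these compounds go, is whether the higher number belongs to tert-butyl alone or extends to other groups on this nitrogen, such as a cyclopropyl ring, a cyclohexyl ring or a longer straight chain like n-butyl. Also open, from the compounds shown here alone, is whether a hydroxyl or an amine placed on a branched chain at this position would bring the number back towards that of compound 2 at 51 nM.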